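The compounds below may be only part of what the source reports. "The series", "measured", "known", "first", "only" and "open" are said of these compounds alone.

Measured so far:
- compound 1, `COc1cccc(CNCCCNc2ccnc3cc(-c4ccc(C(F)(F)F)cc4)ccc23)c1O`: 237 10^-6 cm/s
- compound 2, `FC(F)(F)c1ccc(-c2ccc3c(NCCCNCc4ccco4)ccnc3c2)cc1`: 237 10^-6 cm/s
- compound 3, `c1ccc(CCc2ccc3c(NCCCNCc4ccco4)ccnc3c2)cc1`: 23 10^-6 cm/s

In an ADME assay for permeability, using PAMPA, with a stated time of 30 min, at pH 7.4 (a higher number here means that the compound crosses the layer faster, a lower number that the compound crosses the layer more slowly), compound 1 gives 237 10^-6 cm/s, the same reading as compound 2, and together these two stand at the top of the three numbers. The step of no change at the digits printed from compound 1 to compound 2 (within the scatter) shows that swapping the group on the saturated chain carbon bound to an amine nitrogen left the reading where it was. The step of a 10-fold lower number from compound 2 to compound 3 (1.01 log units; beyond the scatter), by contrast, shows that replacing the 4-(trifluoromethyl)phenyl group on the aromatic carbon of the shared core cost a large amount of permeability.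

Compound 4, `COc1ccccc1Oc1ccc2c(NCCCNCc3cccc(OC)c3O)ccnc2c1`, is not yet measured. It differs from compound 1 as follows: 2-methoxyphenoxy in place of 4-(trifluoromethyl)phenyl on an aromatic carbon. Within the data shown here, this change sits at the same position on the core as the one in the step from compound 2 to compound 3, so that step is the one that bears on it, while the step from compound 1 to compound 2 concerns a different part of the molecule. A drop beyond the scatter is therefore expected, though the group entering here is a different one from phenethyl, so the size is uncertain.

For compound 4 the expected reading in this assay is 80 10^-6 cm/s, with a plausible range from 25 10^-6 cm/s to 240 10^-6 cm/s. This estimate corresponds to a step of a 3.0-fold lower number from compound 1 to compound 4 (0.47 log units; beyond the scatter).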

Compound 4, apparent permeability: 317 10^-6 cm/s
Compound 4: the middle estimate sits 4.0-fold (0.60 log units) below what was measured; the measured number lies above the stated range.
By their numbers in this assay, from the lowest: compound 3; then compounds 1, 2 and 4 (each within the scatter of the next).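

In this assay, the step of a 1.3-fold higher number from compound 1 to compound 4 (0.13 log units; within the scatter) shows that this aromatic carbon can carry 2-methoxyphenoxy in place of 4-(trifluoromethyl)phenyl with the reading staying level, even though the swap removes three fluorine atoms and brings in two oxygen atoms and two hydrogen-bond acceptors. The earlier step at this same position, a 10-fold lower number from compound 2 to compound 3 (1.01 log units; beyond the scatter), therefore cannot be read as a general penalty for replacing 4-(trifluoromethyl)phenyl, since one replacement at this carbon gave a large step and another gave none, although those two replacements were made on compounds that differ at the other end of the chain. Nothing measured here explains why phenethyl and 2-methoxyphenoxy part ways in this way.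

Going by these compounds, it remains open whether 2-methoxyphenoxy would keep the reading with furan-2-yl on the chain, and whether phenethyl would give the same large step with 2-hydroxy-3-methoxyphenyl there. Also open, on these data alone, is how this carbon would respond to a group of a different kind, such as a carboxylic acid or a piperazine, which would test how far the tolerance seen for 2-methoxyphenoxy extends.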